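Swapping a phenyl for a hydroxypiperidine on the sulfonyl group

The source may hold more compounds than are shown below. What is called first, only, known or untested is meant among the compounds shown, and "the series" means these compounds.

Compound 1 `O=C(NCc1ccc(S(=O)(=O)c2ccccc2)cc1)N1Cc2ccncc2C1` is measured in an ADME assay on microsomes from liver (Homo sapiens) for pharmacokinetics, read by LC-MS, with a stated time of 60 min, tested at 1 uM (a higher number here means faster removal of the compound, a lower number slower removal), and gives 7.5 mL/min/kg, the lowest of the three numbers available. Compound 2 `O=C(NCc1ccc(S(=O)(=O)C2CCCCC2)cc1)N1Cc2ccncc2C1` gives 16 mL/min/kg, and compound 3 `CCC(=O)N1CCC(S(=O)(=O)c2ccc(CNC(=O)N3Cc4ccncc4C3)cc2)CC1` gives 11 mL/min/kg. The two measured steps from compound 1 are a 2.1-fold higher number from compound 1 to compound 2 (0.33 log units; beyond the scatter) and a 1.5-fold higher number from compound 1 to compound 3 (0.17 log units; within the scatter), so both changes at the sulfonyl sulfur moved the number upward, one of them only within the scatter.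

Compound 4 `O=C(NCc1ccc(S(=O)(=O)N2CCC(O)CC2)cc1)N1Cc2ccncc2C1` carries a different change at the same place: 4-hydroxypiperidin-1-yl in place of phenyl on a sulfonyl sulfur. Among the measured compounds shown here, no measured step introduces a nitrogen-linked ring with a hydroxyl group here, so the closest guides are the steps to compound 2 and compound 3, both modest or within the scatter. The group entering in compound 4 is polar and unlike the carbon rings in those compounds, which weakens the analogy. The expectation is therefore a step of a 1.1-fold lower number from compound 1 to compound 4 (0.03 log units; within the scatter), essentially none beyond the scatter. Compound 4 is estimated at 7 mL/min/kg, within a range from 3.5 mL/min/kg to 14 mL/min/kg.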

Compound 4, clearance: 6 mL/min/kg
Beside the measured number, compound 4's estimate is 1.2-fold (0.07 log units) above it, within the range that was stated.
By their numbers in this assay, from the lowest: compounds 4, 1, 3 and 2 (each within the scatter of the next, the first and the last beyond it).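

In this assay, a ring joined to the sulfonyl sulfur through nitrogen and carrying a hydroxyl gives a 1.3-fold lower number from compound 1 to compound 4 (0.10 log units; within the scatter), so this change from phenyl stays within the scatter. The step of a 1.8-fold lower number from compound 3 to compound 4 (0.26 log units; within the scatter) also stays within the scatter, while a 2.7-fold lower number from compound 2 to compound 4 (0.43 log units; beyond the scatter) goes beyond it, so on this sulfur 4-hydroxypiperidin-1-yl joins phenyl in standing clear of cyclohexyl. No measurement is available that would explain these numbers.

A piperidin-1-yl without the hydroxyl, or a morpholin-4-yl, on the sulfonyl sulfur would help separate the part played by the hydroxyl from that of the ring nitrogen, and the compounds shown leave this open. How a carboxylic acid or a primary amine in place of that hydroxyl would read in this assay is open as well.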